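This account rests on a few compounds, and the source may have more. Where it says the series, first, only, none or still open, it means among the compounds named here.

Working notes on the series. In a functional assay on NCI-H23 cells (Homo sapiens) for cytotoxicity, read by sulforhodamine B assay, with a stated time of 72 h (a higher number here means a weaker inhibitor of growth, a lower number a stronger inhibitor of growth), compound 1 `CCCC(=O)N1c2ccccc2CCC1C(=O)Nc1cc(C(F)(F)F)cc(C(F)(F)F)c1` gives 15000 nM, and compound 3 `COc1ccc(NC(=O)c2ccc3ccccc3n2)cc1` gives 7650 nM. Compound 2 `CCCC(=O)N1c2ccccc2CCC1C(=O)Nc1ccccc1C(F)(F)F` returns only a limit of this assay, > 70000 nM. Among the numbers shown, compound 2 stands at the limit of > 70000 nM in this assay, at which 1 of the 3 values shown sits, the weak end of the series. Compound 4 `O=C(Nc1ccccc1C(F)(F)F)C1CCc2ccccc2N1C(=O)c1ccccc1Cl` differs from compound 2 by 2-chlorophenyl in place of propyl on a carbonyl carbon. Among the measured compounds shown here, no measured pair shows this change, so its size cannot be read from a comparison. The step expected here, an at least 2.3-fold lower number from compound 2 to compound 4 (0.36 log units; beyond the scatter), is a gain in growth inhibition beyond the scatter, though of uncertain size given that compound 2 has no number. Compound 4 is therefore estimated at 30000 nM, with a range from 8000 nM to 100000 nM.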

Compound 4, concentration for 50% growth inhibition: 2150 nM
Compound 4: the middle estimate sits 14-fold (1.14 log units) above what was measured, outside the stated range (below it).
By their numbers in this assay, from the lowest: compound 4; then compounds 3 and 1 (each within the scatter of the next). At a limit, above all of these: compound 2.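

On a carbonyl carbon whose other neighbour is an amide-type nitrogen in a ring, 2-chlorophenyl in place of propyl gives an at least 32-fold lower number from compound 2 to compound 4 (1.51 log units; beyond the scatter) in this assay. With the rest of compound 2 held fixed, the group on this carbonyl alone carries a change beyond the scatter. Compound 2 gives a limit and not a number, and the step only bounds the size of the change: the limit of > 70000 nM in this assay, at which 1 of the 4 values shown sits.

Going by these compounds, whether the ring or the chlorine carries the gain stays open, a question that phenyl or a longer chain on this carbonyl would address. Also open, on these data alone, is whether the change holds with the amide partner of compound 1.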